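Aryl exchange in a series at its assay limit

This account rests on a few compounds, and the source may have more. Where it says the series, first, only, none or still open, it means among the compounds named here.

Measured in a functional assay on A549 cells (Homo sapiens) for antiproliferative activity, read by MTT assay, with a stated time of 48 h; a lower number here means a stronger inhibitor, a higher number a weaker inhibitor:
- compound 1 `C/C(=C\CC/C(C)=C/CC[C@@H]1[C@@]2(C)CCC(=O)C(C)(C)[C@H]2CC[C@@]1(C)O)CC/C=C(\C)C(=O)OCc1cn(-c2ccc(F)cc2)nn1`: > 150000 nM
- compound 2 `C/C(=C\CC/C(C)=C/CC[C@@H]1[C@@]2(C)CCC(=O)C(C)(C)[C@H]2CC[C@@]1(C)O)CC/C=C(\C)C(=O)OCc1cn(-c2ccccc2C)nn1`: > 150000 nM

Compound 2 stands at > 150000 nM, which is a limit and not a number. Among the measured compounds shown here, the only other value shown, for compound 1, is also a limit.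

Compound 3 `C/C(=C\CC/C(C)=C/CC[C@@H]1[C@@]2(C)CCC(=O)C(C)(C)[C@H]2CC[C@@]1(C)O)CC/C=C(\C)C(=O)OCc1cn(-c2ccc(Cl)cc2)nn1` carries 4-chlorophenyl in place of 2-methylphenyl on an aromatic nitrogen. For the measured compounds named here, one measured step bears on this change: a step that the two limits leave unreadable from compound 1 to compound 2. It exchanges the group on the same nitrogen, but gives no size to carry over. The remaining guide is the limit of > 150000 nM in this assay, at which 2 of the 2 values shown sit. No step beyond the scatter is therefore expected in this assay, and another limit is the likeliest report. The expected step is a step that the limit leaves unreadable from compound 2 to compound 3. The estimate for compound 3 is 160000 nM, with an expected range from 90000 nM to 300000 nM.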

Compound 3, half-maximal inhibitory concentration: > 150000 nM
Compound 3: no number, only a limit; the forecaster's own chance of this, stated with the estimate: 85%; the middle value is on the limit's open side.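

No new step can be read among compound 1, compound 2 and compound 3, since each result is a limit and not a number: the limit of > 150000 nM in this assay, at which 3 of the 3 values shown sit.

The compounds shown leave open whether any aryl group on this aromatic nitrogen gives a measurable value, and how 4-fluorophenyl, 2-methylphenyl and 4-chlorophenyl would rank.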